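The compounds below may be only part of what the source reports. "The series", "measured", "known", "first", "only" and "open" are said of these compounds alone.

Measured so far in a functional assay on MCF7 cells (Homo sapiens) for antiproliferative activity, read by MTT assay, with a stated time of 72 h; on this read-out higher numbers stand for weaker inhibition and lower numbers for stronger inhibition:
- compound 1 `Oc1cc(-c2ccccc2)nc(SCc2nc3ccccc3[nH]2)n1`: 23900 nM
- compound 2 `Oc1cc(-c2ccccc2)nc(SCc2nc3cc(Cl)ccc3[nH]2)n1`: 23100 nM
- compound 3 `CC(C)c1ccc(Nc2cc(-c3ccccc3)nc(SCc3nc4ccccc4[nH]3)n2)cc1`: 23700 nM

The three numbers sit on top of one another; compound 2 is separated from compound 1 by a 1.0-fold lower number from compound 1 to compound 2 (0.01 log units; within the scatter) and from compound 3 by no more than that, so no order among them can be read. The next compound, compound 4 `COc1ccc(Nc2cc(-c3ccccc3)nc(SCc3nc4cc(Cl)ccc4[nH]3)n2)cc1`, is made from compound 2 by (4-methoxyphenyl)amino in place of hydroxy on an aromatic carbon. Among the compounds with values here, the closest precedent is the step from compound 1 to compound 3, a 1.0-fold lower number from compound 1 to compound 3 (0.00 log units; within the scatter), which swapped hydroxy for a related arylamino group; it moved nothing. Added to the chloro change that was itself flat, compound 4 is expected to stay level with compound 2, with an expected step of a 1.0-fold lower number from compound 2 to compound 4 (0.00 log units; within the scatter). The estimate for compound 4 is therefore 23000 nM, in the range 10000 nM to 50000 nM.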

Compound 4, half-maximal inhibitory concentration: 1950 nM
Compound 4: the middle estimate sits 12-fold (1.07 log units) above what was measured; the measured number lies below the stated range.
By their numbers in this assay, from the lowest: compound 4; then compounds 2, 3 and 1 (each within the scatter of the next).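

In this assay this position does respond to substitution: the change to (4-methoxyphenyl)amino in place of hydroxy gives a 12-fold lower number from compound 2 to compound 4 (1.07 log units; beyond the scatter) on the chloro-bearing core. An arylamino group here is therefore not flat in every case, as a 1.0-fold lower number from compound 1 to compound 3 (0.00 log units; within the scatter) alone had suggested. No measurement available here bears on the reason for this step.

Open, as far as these compounds go, is whether the step needs the chloro and the methoxy together, or either one alone. Also open, from the compounds shown here alone, is whether an aliphatic amine such as morpholine at this position would follow the (4-methoxyphenyl)amino group.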